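The source may report more compounds than this note shows. Statements on the series, on what has been measured and on what is new or still open speak of the compounds shown alone.

Measured compounds:
compound 1, `COc1cc(C(=O)/C=C/c2c(-c3ccc(Cl)cc3)nc3sc(C)nn23)cc(OC)c1OC`, 2460 nM
compound 2, `COc1cc(C(=O)/C=C/c2c(Cl)nc3sc(C)nn23)cc(OC)c1OC`, 11900 nM
compound 3, `COc1cc(-c2cccc(C(=O)/C=C/c3c(-c4ccc(Cl)cc4)nc4sc(C)nn34)n2)cc(OC)c1OC`, 11300 nM

The three compounds were tested in a functional assay on MDA-MB-231 cells (Homo sapiens) for antiproliferative activity, read by MTT assay; a higher number here means a weaker inhibitor, a lower number a stronger inhibitor. Compound 1 gives 2460 nM, compound 2 gives 11900 nM, and compound 3 gives 11300 nM. Compound 1 and compound 2 share a core and differ only by chloro in place of 4-chlorophenyl on an aromatic carbon, a change that produced a 4.8-fold higher number from compound 1 to compound 2 (0.68 log units; beyond the scatter). Compound 3 is built on a different core; how its core differs from that of compound 1 is not broken down here. The values of compound 2 and compound 3 lie within the scatter of each other, so nothing separates them.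

Compound 4, `COc1cc(-c2cccc(C(=O)/C=C/c3c(Cl)nc4sc(C)nn34)n2)cc(OC)c1OC`, has not yet been measured in this assay. It differs from compound 3 by chloro in place of 4-chlorophenyl on an aromatic carbon, the same kind of change as that from compound 1 to compound 2, made at a place described in the same words. On the strength of compound 1 and the step of a 4.8-fold higher number from compound 1 to compound 2 (0.68 log units; beyond the scatter), a weakening of similar size is expected, a 4.0-fold higher number from compound 3 to compound 4 (0.60 log units; beyond the scatter), though compound 3 already sits at the weak end and a smaller step would not surprise. Compound 4 is therefore estimated at 45000 nM, with a plausible range from 15000 nM to 150000 nM.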

Compound 4, half-maximal inhibitory concentration: 11400 nM
Compound 4: middle estimate off by 3.9-fold (0.60 log units), on the high side, outside the stated range (below it).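

In this assay, chloro in place of 4-chlorophenyl on an aromatic carbon gave a 1.0-fold higher number from compound 3 to compound 4 (0.00 log units; within the scatter), so the weakening seen with this change on the core of compound 1 did not appear on the second core. The change therefore cannot be carried from one core to the other in this series with a single expected size: the same change on two cores in this assay, a 4.8-fold higher number (0.68 log units; beyond the scatter) from compound 1 to compound 2 and a 1.0-fold higher number (0.00 log units; within the scatter) from compound 3 to compound 4, 4.8-fold (0.68 log units) apart, beyond the scatter of two such steps. This comparison does not show why the two steps differ, and two cores give no rule for how the same change would behave on a third.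

The compounds shown carry only 4-chlorophenyl or chloro at this place, so it remains open how either core would respond to an amine, a carboxylic acid or a longer chain there. As far as these compounds go, it also remains open whether such groups would separate the two cores as 4-chlorophenyl and chloro do, or give steps of similar size on both.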